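Working notes: methyl for hydrogen on an oxygen, antiproliferative series

The source may report more compounds than this note shows. Statements on the series, on what has been measured and on what is new or still open speak of the compounds shown alone.

Measured so far in a functional assay on HT-1080 cells (Homo sapiens) for antiproliferative activity, read by MTT assay, with a stated time of 72 h; on this read-out higher numbers stand for weaker inhibition and lower numbers for stronger inhibition:
Compound 1 `COc1ccc(-c2ss/c(=N/O)c2-c2cc(OC)c(OC)c(OC)c2)cc1N` gives 9360 nM.
Compound 2 `COc1ccc(-c2c(-c3cc(OC)c(OC)c(OC)c3)ss/c2=N/O)cc1[N+](=O)[O-]` gives 3030 nM.
Compound 3 `CO/N=c1/ssc(-c2ccc(OC)c(N)c2)c1-c1cc(OC)c(OC)c(OC)c1` gives 4230 nM.

Compound 1 and compound 3 differ in one place: methyl in place of hydrogen on an oxygen. The step this made, a 2.2-fold lower number from compound 1 to compound 3 (0.34 log units; beyond the scatter), is modest in size but lies beyond the usual scatter, so it is taken as a real shift rather than noise.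

Compound 2 carries a different core from compound 1; the difference between the two cores is not broken down here. Its value stands beyond the scatter lower than that of compound 1, while against compound 3 the gap is within the scatter, so no order between compound 2 and compound 3 is claimed.

Compound 4 `CO/N=c1/ssc(-c2cc(OC)c(OC)c(OC)c2)c1-c1ccc(OC)c([N+](=O)[O-])c1` has not yet been measured. It relates to compound 2 as compound 3 relates to compound 1: methyl in place of hydrogen on an oxygen. The place of the change is described in the same words for both pairs, so this is the same change, now made on the core of compound 2. Among the measured compounds shown here, only the one precedent exists, and it sits on a different core, so the expectation is held loosely.

In this assay compound 4 is expected to show a step of about the size seen before, a 1.9-fold lower number from compound 2 to compound 4 (0.28 log units; within the scatter), because compound 1 to compound 3 gave a 2.2-fold lower number from compound 1 to compound 3 (0.34 log units; beyond the scatter). The estimate for compound 4 is 1600 nM, with a range from 700 nM to 3600 nM.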

Compound 4, half-maximal inhibitory concentration: > 100000 nM
Compound 4: a limit, no number; the forecaster's own chance of this, stated with the estimate: 0%; middle value at least 62-fold (1.79 log units) from the limit.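

In this assay compound 4 gives > 100000 nM, which is a limit of the assay and not a number. On the core of compound 2, hydroxy to methoxy gives an at least 33-fold higher number from compound 2 to compound 4 (1.51 log units; beyond the scatter), so the step seen on the core of compound 1 does not carry over to this core in either direction or size: the same change on two cores in this assay, a 2.2-fold lower number (0.34 log units; beyond the scatter) from compound 1 to compound 3 and an at least 33-fold higher number (1.51 log units; beyond the scatter) from compound 2 to compound 4, at least 73-fold (1.86 log units) apart, beyond the scatter of two such steps The result rests on two pairs only: it shows that the same change can have opposite outcomes on these two cores, but it does not give the full size of the new step, does not identify which difference between the cores is responsible, and does not support a rule for any other core in the series.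

The compounds shown leave open whether the sharp loss on the core of compound 2 is specific to methyl or would also appear with a longer chain on the same oxygen, such as ethyl or benzyl. They also leave open how an acetyl group on that oxygen would behave on each core, and whether such replacements would again separate the two cores or bring them into line.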